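Adding a second fluorine to the aryl ring of compound 3

This account rests on a few compounds, and the source may have more. Where it says the series, first, only, none or still open, it means among the compounds named here.

Measured compounds:
Compound 1, `N#Cc1c(N2CCC(c3ccccc3)CC2)ccn(CCC2CC2)c1=O`: 316%
Compound 2, `N#Cc1c(N2CCC(c3ccccc3F)CC2)ccn(CC2CC2)c1=O`: 282%
Compound 3, `N#Cc1c(N2CCC(c3ccc(F)cc3)CC2)ccn(CC2CC2)c1=O`: 258%

Of the compounds shown here, three sharing one core have been measured in a functional assay on CHO cells for positive allosteric modulation of metabotropic glutamate receptor 2 (Homo sapiens), with a stated time of 30 min; a higher number here means a larger maximal response, a lower number a smaller maximal response. Compound 1, `N#Cc1c(N2CCC(c3ccccc3)CC2)ccn(CCC2CC2)c1=O`, gives 316%. Compound 2, `N#Cc1c(N2CCC(c3ccccc3F)CC2)ccn(CC2CC2)c1=O`, gives 282%. Compound 3, `N#Cc1c(N2CCC(c3ccc(F)cc3)CC2)ccn(CC2CC2)c1=O`, gives 258%, the lowest of the three, lying beyond the scatter below both others.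

Compound 4, `N#Cc1c(N2CCC(c3ccc(F)cc3F)CC2)ccn(CC2CC2)c1=O`, is not yet measured. It differs from compound 3 by fluoro in place of hydrogen on an aromatic carbon, which, read one bond further out, is 4-fluorophenyl to 2,4-difluorophenyl.

Among the compounds with values here, one measured step bears on this change: a number 24 percentage points lower from compound 2 to compound 3 (beyond the scatter). It shows that a fluoro at the 2-position gave a modestly larger maximal response than a fluoro at the 4-position. Compound 4 carries both. Within the data shown here, with only this single step as a guide, a small upward move for compound 4 is expected, though a step within the scatter would not surprise.

In this assay compound 4 is therefore estimated at 270%, within 215% to 325%, which means an expected step of a number 12 percentage points higher from compound 3 to compound 4 (beyond the scatter).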

Compound 4, largest response reached (Emax), in percent of the reference or control that the assay uses: 272%
Compound 4: middle estimate off by 2 percentage points, on the low side, within the range that was stated.
By their numbers in this assay, from the lowest: compound 3; then compounds 4 and 2 (each within the scatter of the next); then compound 1.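

In this assay, the direct change from 4-fluorophenyl to 2,4-difluorophenyl, which places fluoro on the aromatic carbon ortho to a large group, gives a number 14 percentage points higher from compound 3 to compound 4 (beyond the scatter), so this position has now been tested by a single replacement of hydrogen rather than only by comparing two singly fluorinated isomers. The second available route to the same 2,4-difluorophenyl group reads differently, with the change from 2-fluorophenyl giving a number 10 percentage points lower from compound 2 to compound 4 (within the scatter), so across these compounds the added fluoro gives a step beyond the scatter in one setting and not in the other. No measurement shown here explains why the same kind of change reads differently in these two settings.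

Within the data shown here, it remains open whether a chloro or methoxy group on the same aromatic carbon would give a step like that of fluoro, since fluoro is the only group tested there. Going by these compounds, it is also open whether the 2,4-difluorophenyl group would give a similar response when combined with the longer chain carried by compound 1.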